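This account rests on a few compounds, and the source may have more. Where it says the series, first, only, none or still open, it means among the compounds named here.

Measured so far:
- compound 1, `O=C(NCc1ccc(CNS(=O)(=O)c2ccccc2)cc1)c1cccnc1`: 10 nM
- compound 2, `Cc1ccc(S(=O)(=O)NCc2ccc(CNC(=O)c3ccc(Cl)cc3)cc2)cc1`: 10 nM

In an assay on MDA-MB-231 cells for binding affinity to C-X-C chemokine receptor type 4 (Homo sapiens), read by immunofluorescence and microscopy, with stated times of 10 min and 30 min (on this read-out lower numbers stand for an effect already at smaller amounts and higher numbers for an effect only at larger amounts of compound), compound 1 gives 10 nM and compound 2 gives 10 nM; at the digits shown the two are level, and their values lie within the scatter of one another. Among the measured compounds shown here, no single-point step between them is drawn, since compound 2 differs from compound 1 at two places, on the carbonyl side and on the sulfonyl side, so the pair says only that both arrangements land at the same level of effect.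

Compound 3, `Cc1ccc(C(=O)NCc2ccc(CNS(=O)(=O)c3ccccc3)cc2)cc1`, keeps the sulfonyl side of compound 1 and changes only the amide side: 4-methylphenyl in place of pyridin-3-yl on a carbonyl carbon. Nothing measured isolates this change. What the two measured compounds show is that the amide-side aryl tolerates replacement of the pyridin-3-yl group without a visible shift in this assay, so no step beyond the scatter is expected, and no change at the digits printed from compound 1 to compound 3 (within the scatter) is the estimated step. Compound 3 is accordingly expected to give about 10 nM, within 4 nM to 30 nM.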

Compound 3, effective concentration (reported as EC, without a stated level of effect): 100 nM
Estimate against measurement, compound 3: 10-fold (1.00 log units) below, and the stated range ends below it.
By their numbers in this assay, from the lowest: compounds 1 and 2 (each within the scatter of the next); then compound 3.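

Replacing pyridin-3-yl with 4-methylphenyl on a carbonyl carbon gives a 10-fold higher number from compound 1 to compound 3 (1.00 log units; beyond the scatter) in this assay, so this position does not accept every aryl group on the core of compound 1 without a shift. The change removes a ring nitrogen, counted as a hydrogen-bond acceptor, and adds a methyl group in one move, and this single step cannot separate the two contributions. No available measurement explains the higher number.

Still open, as far as these compounds go, is whether a plain phenyl group, which has neither the ring nitrogen nor the methyl, would read closer to compound 1 or to compound 3. Also open, from the compounds shown here alone, are whether the step carries over to other groups on the sulfonyl side and how a pyridin-4-yl group or an aminomethyl-substituted phenyl group would read at this position.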